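Replacing a Hydroxymethyl Group on a Fused Core: Exposure Outlook

The compounds below may be only part of what the source reports. "The series", "measured", "known", "first", "only" and "open" are said of these compounds alone.

Measured compounds:
- compound 1 `CCCCN(c1nc2c(CO)cccc2o1)[C@H](C)c1ccc(-c2ccccc2-c2nnn[nH]2)cc1`: 20.7 nM
- compound 2 `CCCCN(c1nc2c(NS(C)(=O)=O)cccc2o1)[C@H](C)c1ccc(-c2ccccc2-c2nnn[nH]2)cc1`: 49.9 nM

Of the compounds shown here, two built on the same core have been tested in an ADME assay on the whole organism (Macaca fascicularis) for pharmacokinetics, read by LC-MS, using cassette dosing, at a dose of 1 mg/kg by the oral route; a lower number here means less compound in the circulation, a higher number more compound in the circulation at the dose given. Compound 1 gives the lower of the two numbers, 20.7 nM, while compound 2 gives 49.9 nM. Within the data shown here, the one change tracked between them, a 2.4-fold higher number from compound 1 to compound 2 (0.38 log units; beyond the scatter), shows that swapping the group on this aromatic carbon can move the maximal plasma concentration by a modest amount.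

Compound 3 `CCCCN(c1nc2c(-c3nccn3C)cccc2o1)[C@H](C)c1ccc(-c2ccccc2-c2nnn[nH]2)cc1` is not yet measured in this assay. It differs from compound 1 in that place: 1-methyl-1H-imidazol-2-yl in place of hydroxymethyl on an aromatic carbon. Among the measured compounds shown here, the one measured step bears on it only loosely, since the group entering here is a ring rather than a sulfonamide, so the direction is not settled by the data. The step is expected to be small, a 1.4-fold higher number from compound 1 to compound 3 (0.16 log units; within the scatter), most likely within or just beyond the scatter, and on the higher side if anything. Compound 3 is therefore estimated at 30 nM, with a range from 8 nM to 110 nM.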

Compound 3, maximal plasma concentration: 154 nM
For compound 3 the middle estimate is 5.1-fold (0.71 log units) below the measured one, outside the stated range (above it).
By their numbers in this assay, from the lowest: compound 1; then compound 2; then compound 3.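

The size of the change at this position is larger than the first pair suggested: in this assay the 1-methyl-1H-imidazol-2-yl group gives a 7.4-fold higher number from compound 1 to compound 3 (0.87 log units; beyond the scatter) and so the largest step among these compounds. The ring also outperforms the methanesulfonamido group on this aromatic carbon, with a 3.1-fold higher number from compound 2 to compound 3 (0.49 log units; beyond the scatter) showing that the gain is not merely a matter of removing hydroxymethyl. Compared with hydroxymethyl, the ring brings more heavy atoms, an aromatic ring and no hydrogen-bond donor, but these differences arrive together, and nothing measured here separates them or explains the rise.

The compounds shown leave open whether the methyl on the imidazole ring matters, and a plain imidazole or a pyridine on the same carbon would help to test whether this result is specific to 1-methyl-1H-imidazol-2-yl or extends to other aromatic rings. Going by these compounds, they also leave open how a small group such as an amine or a carboxylic acid would behave here, and since every comparison rests on a single read-out, the wider pharmacokinetic picture for compound 3 remains unknown.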